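Cyclobutyl amide in place of thiophene amide on compound 3

The compounds below may be only part of what the source reports. "The series", "measured", "known", "first", "only" and "open" are said of these compounds alone.

In an assay on isolated protein for inhibition of serine/threonine-protein kinase TBK1 (Homo sapiens) (a higher number here means a weaker inhibitor, a lower number a stronger inhibitor), compound 3 `O=C(NCCCNc1nc(Nc2cccc(F)c2)ncc1Br)c1cccs1` gives 9 nM, the lowest of the two numbers shown. Compound 1 `O=C(NCCCNc1nc(Nc2cccc(F)c2)ncc1Br)c1ccc(C(F)(F)F)cc1` gives 450 nM in this assay. The step of a 50-fold lower number from compound 1 to compound 3 (1.70 log units; beyond the scatter) shows that the group on the carbonyl carbon moves this assay strongly. Compound 2 `CC(C)c1cnc(Nc2cccc(F)c2)nc1NCCCNC(=O)C1CCC1` gives > 1000 nM in this assay, which is a limit of the assay and not a number. Compound 4 `O=C(NCCCNc1nc(Nc2cccc(F)c2)ncc1Br)C1CCC1` differs from compound 3 by cyclobutyl in place of thiophen-2-yl on a carbonyl carbon. Among the compounds with values here, no measured step covers this exact exchange; the only bearing step, a 50-fold lower number from compound 1 to compound 3 (1.70 log units; beyond the scatter), shows how wide the swing at this position can be. A weakening step a 17-fold higher number from compound 3 to compound 4 (1.22 log units; beyond the scatter) is therefore expected. Compound 4 is estimated at 150 nM, between 30 nM and 800 nM.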

Compound 4, half-maximal inhibitory concentration: 2 nM
Compound 4: middle estimate off by 75-fold (1.88 log units), on the high side; measured number outside the range, below it.
By their numbers in this assay, from the lowest: compound 4; then compound 3; then compound 1. At a limit, above all of these: compound 2.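

In this assay, an aromatic ring on the carbonyl carbon is not required: cyclobutyl gives a 4.5-fold lower number from compound 3 to compound 4 (0.65 log units; beyond the scatter), and against 4-(trifluoromethyl)phenyl it gives a 230-fold lower number from compound 1 to compound 4 (2.35 log units; beyond the scatter). With the cyclobutyl amide held constant, bromo in place of isopropyl on an aromatic carbon gives an at least 500-fold lower number from compound 2 to compound 4 (2.69 log units; beyond the scatter), so the substituent on the aromatic carbon also matters strongly. Compound 2 stands at a limit and not a number: the limit of > 1000 nM in this assay, at which 1 of the 4 values shown sits.

Still open, going by these compounds, is whether piperidin-4-yl or an open chain such as isobutyl on the carbonyl carbon would keep the number this low. Also open, on these data alone, is whether chloro could stand in place of bromo.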